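The compounds below may be only part of what the source reports. "The series", "measured", "known", "first", "only" and "open" are said of these compounds alone.

Measured so far:
- compound 1 `COc1cc(/C=C/C(=O)/C=C(/C=C/c2ccc(OC(C)=O)c(OC)c2)NC2CCCCC2)ccc1OC(C)=O` gives 9700 nM
- compound 2 `COc1cc(/C=C/C(=O)/C=C(/C=C/c2ccc(O)c(OC)c2)NC2CCCCC2)ccc1O` gives > 25000 nM

Among the compounds with values here, in a functional assay on Caco-2 cells (Homo sapiens) for inhibition, read by MTT assay, with a stated time of 72 h (a higher number here means a weaker inhibitor, a lower number a stronger inhibitor), compound 1 gives 9700 nM as the only actual number so far. Compound 2 stands at > 25000 nM, which is a limit of the assay and not a number.

The next compound to be read is compound 3 `CCC(C)NC(=C\C(=O)/C=C/c1ccc(OC(C)=O)c(OC)c1)/C=C/c1ccc(OC(C)=O)c(OC)c1`, which keeps the core of compound 1 and carries sec-butyl in place of cyclohexyl on an amine nitrogen. The counted difference reads (sec-butyl in place of cyclohexyl on an amine nitrogen).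

Within the data shown here, no measured step covers this change, so nothing gives its size directly. The expectation therefore rests on compound 1 with its 9700 nM as the anchor, and no shift beyond the scatter is expected in this assay in either direction. The expected move is a 1.0-fold higher number from compound 1 to compound 3 (0.01 log units; within the scatter), which is an estimate only. For compound 3 the estimated value is 10000 nM, with an expected range from 4500 nM to 24000 nM.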

Compound 3, half-maximal inhibitory concentration: > 25000 nM
Compound 3 was reported as a limit; the forecaster's own chance of this, stated with the estimate: 15%; middle value at least 2.5-fold (0.39 log units) from the limit.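

In this assay, the group on an amine nitrogen proves to matter: sec-butyl in place of cyclohexyl, with the core of compound 1 kept, gives an at least 2.5-fold higher number from compound 1 to compound 3 (0.41 log units; beyond the scatter). Compound 3 gives > 25000 nM, which is a limit of the assay and not a number. The step is therefore a floor, and its full size cannot be read from the series, since the reading stops at the same limit that recurs across the compounds shown: the limit of > 25000 nM in this assay, at which 2 of the 3 values shown sit.

The change removes the six-membered non-aromatic ring and shortens the carbon group in one move, so the compounds shown do not separate the loss of the ring from the loss of size; an open chain such as n-hexyl or a smaller ring such as cyclopentyl on the same nitrogen would bear on that. Within the data shown here, it also stays open whether any group on this nitrogen gives a lower number than compound 1 at 9700 nM, as cyclohexyl is the only group here that gives an actual number in this assay.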